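Swapping Acetyl for Cyano in a Growth Inhibitor Series

This account rests on a few compounds, and the source may have more. Where it says the series, first, only, none or still open, it means among the compounds named here.

Compound 1, `COc1ccc(-c2[nH]c3ccccc3c2/C=C(\C#N)S(=O)(=O)c2ccccc2)cc1`: 649 nM
Compound 2, `CC(=O)/C(=C\c1c(-c2ccccc2)[nH]c2ccccc12)S(=O)(=O)c1ccccc1`: 1700 nM
Compound 3, `COc1ccc(-c2[nH]c3ccc(OC)cc3c2C=C(C#N)C#N)cc1`: 1300 nM

The three compounds were tested in a functional assay on MDA-MB-231 cells (Homo sapiens) for inhibition, read by sulforhodamine B assay, with a stated time of 48 h; on this read-out lower numbers stand for stronger inhibition of growth and higher numbers for weaker inhibition of growth. Among them compound 2 has the highest number. Its gap to compound 3 is small and lies within the usual scatter, so the two cannot be told apart; its gap to compound 1 is larger and lies beyond the scatter, so compound 1 inhibits growth more strongly than compound 2.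

Compound 4, `N#C/C(=C\c1c(-c2ccccc2)[nH]c2ccccc12)S(=O)(=O)c1ccccc1`, has not been measured yet. It is derived from compound 2 by one change: cyano in place of acetyl on a double-bonded chain carbon bound to a double-bonded chain carbon and a sulfonyl sulfur. Among the compounds with values here, no pair of measured compounds differs in only one place, so the size of this step cannot be read from a measured example. Within the data shown here, the only hint is that compound 1, which carries a cyano in the same place but also differs elsewhere, gives 649 nM, the lowest number seen. On that basis the step from compound 2 to compound 4 is expected to be a moderate lowering, a 2.0-fold lower number from compound 2 to compound 4 (0.30 log units; within the scatter), possibly beyond the scatter. Compound 4 is therefore estimated at 850 nM, with a likely range from 300 nM to 2500 nM.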

Compound 4, concentration for 50% growth inhibition: 3800 nM
Estimate against measurement, compound 4: 4.5-fold (0.65 log units) below; the measured number lies above the stated range.
By their numbers in this assay, from the lowest: compounds 1, 3 and 2 (each within the scatter of the next, the first and the last beyond it); then compound 4.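

In this assay, cyano in place of acetyl on a double-bonded chain carbon bound to a double-bonded chain carbon and a sulfonyl sulfur gives a 2.2-fold higher number from compound 2 to compound 4 (0.35 log units; beyond the scatter), so this change weakens growth inhibition, and by more than the scatter. A cyano at this place therefore does not bring strong inhibition by itself: hydrogen in place of methoxy on an aromatic carbon gives a 5.9-fold higher number from compound 1 to compound 4 (0.77 log units; beyond the scatter), which ties the low number of compound 1 to its methoxy and not to the cyano alone. Nothing available explains why either change shifts the read-out in this direction.

The compounds shown leave open whether a methyl ester or a longer acyl chain such as propanoyl at this same place would sit closer to the acetyl of compound 2 or to the cyano of compound 4. They also leave open whether swapping acetyl for cyano has the same effect when the methoxy is present, and whether a fluorine or an amine in place of that methoxy would act as the methoxy does.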